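Ring substitution on the shared core: compound 1 to compound 3

The source may hold more compounds than are shown below. What is called first, only, known or untested is meant among the compounds shown, and "the series" means these compounds.

Compound 1 `C(=N/Nc1nc(-c2ccccc2)cs1)\c1ccc(N2CCCC2)cc1` gives 25600 nM in an assay on isolated protein for inhibition of Amine oxidase [flavin-containing] A (Homo sapiens), read by fluorescence and Amplex Red, with a stated time of 30 min (a lower number here means a stronger inhibitor, a higher number a weaker inhibitor), the lowest of the two numbers recorded so far; the nearest is compound 2 `N#Cc1ccc(-c2csc(N/N=C/c3ccc(N4CCCC4)cc3)n2)cc1`, which in this assay gives 66300 nM. Among the measured compounds shown here, the only measured step, a 2.6-fold higher number from compound 1 to compound 2 (0.41 log units; beyond the scatter), covers cyano in place of hydrogen on an aromatic carbon, a substituent added to the same ring that is altered in compound 3 `Fc1ccc(-c2csc(N/N=C/c3ccc(N4CCCC4)cc3)n2)c(F)c1`. Compound 3 differs from compound 1 by 2,4-difluorophenyl in place of phenyl on an aromatic carbon. For the measured compounds named here, no measured compound carries fluorine, so the comparison is loose. Going by the values given here, with a 2.6-fold higher number from compound 1 to compound 2 (0.41 log units; beyond the scatter) as the only guide, a modest weakening or no step beyond the scatter is expected for compound 3 in this assay. The estimate for compound 3 is therefore 35000 nM, with a range of 15000 nM to 90000 nM. This estimate means an expected step of a 1.4-fold higher number from compound 1 to compound 3 (0.14 log units; within the scatter).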

Compound 3, half-maximal inhibitory concentration: 15600 nM
Compound 3: middle estimate off by 2.2-fold (0.35 log units), on the high side; measured number inside the range.
By their numbers in this assay, from the lowest: compounds 3 and 1 (each within the scatter of the next); then compound 2.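

In this assay, 2,4-difluorophenyl in place of phenyl on this aromatic carbon gives a 1.6-fold lower number from compound 1 to compound 3 (0.22 log units; within the scatter), so substitution on this phenyl ring does not always give the higher number seen with the cyano group. 2,4-Difluorophenyl in place of 4-cyanophenyl gives a 4.3-fold lower number from compound 2 to compound 3 (0.63 log units; beyond the scatter), showing that the identity of the substituents at this position can shift the number beyond the scatter. No measurement at hand explains the gap between these two substituted rings.

Still open, going by these compounds, is whether a single fluorine on this phenyl ring, in either of the two places used in 2,4-difluorophenyl, would give the same reading as the pair. Also open, on these data alone, is what a methoxy group or an amine on this ring would give.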